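Compound 2 to compound 3: replacing the anilide ring

The source may hold more compounds than are shown below. What is called first, only, known or untested is meant among the compounds shown, and "the series" means these compounds.

In a functional assay on HT-29 cells (Homo sapiens) for cytotoxicity, read by MTT assay, with a stated time of 72 h (a higher number here means a weaker inhibitor, a lower number a stronger inhibitor), compound 1, `O=C(CN1CCN(c2nnc(Cc3ccccc3)c3ccccc23)CC1)Nc1ccc(F)c(C(F)(F)F)c1`, gives 4590 nM. Among the compounds with values here, compound 2, `O=C(CN1CCN(c2nnc(Cc3ccccc3)c3ccccc23)CC1)Nc1ccc(F)c(Cl)c1`, gives 13300 nM, the highest of the two numbers so far. Compound 3, `O=C(CN1CCN(c2nnc(Cc3ccccc3)c3ccccc23)CC1)Nc1cccc(Br)c1`, is not yet measured. Its change is 3-bromophenyl in place of 3-chloro-4-fluorophenyl on an amide-type nitrogen, which puts 3-bromophenyl in place of 3-chloro-4-fluorophenyl on an amide-type nitrogen. Within the data shown here, only one measured step bears on this: a 2.9-fold higher number from compound 1 to compound 2 (0.46 log units; beyond the scatter), a modest step beyond the scatter, with chloro in place of trifluoromethyl on an aromatic carbon. Among the measured compounds shown here, no measured compound carries 3-bromophenyl, so the direction is poorly supported. A step of similar or smaller size is therefore expected in this assay, leaning slightly towards a lower number. The expected move is a 1.5-fold lower number from compound 2 to compound 3 (0.17 log units; within the scatter), which may not exceed the scatter. For compound 3 the estimated value is 9000 nM, with an expected range of 3500 nM to 22000 nM.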

Compound 3, half-maximal inhibitory concentration: 13400 nM
For compound 3 the middle estimate is 1.5-fold (0.17 log units) below the measured one; the measured number falls inside the stated range.
By their numbers in this assay, from the lowest: compound 1; then compounds 2 and 3 (each within the scatter of the next).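

Reading a 1.0-fold higher number from compound 2 to compound 3 (0.00 log units; within the scatter) in this assay shows no separation between 3-chloro-4-fluorophenyl and 3-bromophenyl on the amide-type nitrogen, so this change of ring leaves the number within the scatter. Reading a 2.9-fold higher number from compound 1 to compound 3 (0.47 log units; beyond the scatter) for 3-bromophenyl in place of 4-fluoro-3-(trifluoromethyl)phenyl puts compound 3 with compound 2, and among the three compounds only compound 1, with its trifluoromethyl group, stands apart beyond the scatter. No measurement shown offers a reason for either step.

Still open, going by these compounds, is whether a halogen on this ring matters at all, which an unsubstituted phenyl or a methoxy-bearing phenyl would test. Also open, on these data alone, is whether trifluoromethyl keeps its step without the fluoro group, as in 3-(trifluoromethyl)phenyl, and how an amine or a carboxylic acid on the ring would read.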